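Moving a hydroxyl on a pyridine-linked phenol

The source may hold more compounds than are shown below. What is called first, only, known or untested is meant among the compounds shown, and "the series" means these compounds.

The series is read in a functional assay on HeLa cells (Homo sapiens) for cytotoxicity, read by CCK-8 assay; a lower number here means a stronger inhibitor, a higher number a weaker inhibitor. Compound 1, `Oc1ccc(-c2cc(-c3ccoc3)cc(-c3ccccc3O)n2)cc1`, reaches only the limit of the assay, giving > 50000 nM. Compound 2, `Oc1cccc(-c2cc(-c3ccoc3)cc(-c3cccc(O)c3)n2)c1`, gives 4630 nM in this assay. Compound 2 thus holds the only actual number shown; the other value reported is a limit, as the limit of > 50000 nM in this assay, at which 1 of the 2 values shown sits, records. Compound 3, `Oc1ccc(-c2cc(-c3ccoc3)cc(-c3cccc(O)c3)n2)cc1`, has not yet been measured. It differs from compound 2 by 4-hydroxyphenyl in place of 3-hydroxyphenyl on an aromatic carbon, so that one phenol keeps its hydroxyl in the 3-position while the other carries it in the 4-position. Going by the values given here, no step between measured compounds is available to calibrate this change. Compound 3 is expected to be somewhat weaker in this assay, with the step of a 3.0-fold higher number from compound 2 to compound 3 (0.48 log units; beyond the scatter) judged to lie beyond the usual scatter, though a result inside the scatter cannot be excluded. Compound 3 is accordingly estimated at 14000 nM, within a range from 4000 nM to 50000 nM.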

Compound 3, half-maximal inhibitory concentration: 3310 nM
Beside the measured number, compound 3's estimate is 4.2-fold (0.63 log units) above it; measured number outside the range, below it.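

In this assay, 4-hydroxyphenyl in place of 3-hydroxyphenyl on the aromatic carbon next to the ring nitrogen gives a 1.4-fold lower number from compound 2 to compound 3 (0.15 log units; within the scatter), so this change leaves the read-out within the scatter. The change from a 2-hydroxyphenyl to a 3-hydroxyphenyl group, with a 4-hydroxyphenyl group on the other side, is of a different order: it gives an at least 15-fold lower number from compound 1 to compound 3 (1.17 log units; beyond the scatter). The value of compound 1 is a limit of the assay and not a number: the limit of > 50000 nM in this assay, at which 1 of the 3 values shown sits.

The compounds shown leave open how an amine or a methoxy group would read in place of either hydroxyl. They also leave open what happens when the furan-3-yl group gives way to another ring, such as thiophene or a plain phenyl.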